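Exchanging one ring from compound 3 to compound 4

A few compounds are considered here, and "the series" means these few. Any claim that something is new, unique, unknown or untested is made for them only; others in the source may bear on it.

Compound 1 `Cc1cc(C)cc(S(=O)(=O)c2c(C(=O)Nc3ccc(O)cc3)[nH]c3ccc(Cl)cc23)c1`: 18100 nM
Compound 2 `Cc1cc(C)cc(S(=O)(=O)c2c(C(=O)NCc3ccccc3N)[nH]c3ccc(Cl)cc23)c1`: 46200 nM
Compound 3 `Cc1cc(C)cc(S(=O)(=O)c2c(C(=O)NCc3cc(O)ncn3)[nH]c3ccc(Cl)cc23)c1`: > 53000 nM, a limit and not a number

In an ADME assay on MT4 cells (Homo sapiens) for cytotoxicity, read by MTT assay (a lower number here means that less compound is tolerated, a higher number that more compound is tolerated), compound 3 stands at the limit of > 53000 nM in this assay, at which 1 of the 3 values shown sits. Compound 4 `COc1cc(CNC(=O)c2[nH]c3ccc(Cl)cc3c2S(=O)(=O)c2cc(C)cc(C)c2)ccc1O` keeps the shared core, but 4-hydroxy-3-methoxyphenyl comes in place of 6-hydroxypyrimidin-4-yl on a saturated chain carbon bound to an amide-type nitrogen: 4-hydroxy-3-methoxyphenyl in place of 6-hydroxypyrimidin-4-yl on a saturated chain carbon bound to an amide-type nitrogen.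

The new ring is of carbon only, and two measured steps bear on that. The first is an at least 2.9-fold higher number from compound 1 to compound 3 (0.46 log units; beyond the scatter), which brought in a ring with hetero atoms in place of a ring of carbon only. The second goes against a firm rule: an at least 1.1-fold higher number from compound 2 to compound 3 (0.05 log units; that floor lies within the scatter). Read backwards, these steps suggest a modest move to a lower number, meaning that less compound would be tolerated, although a reading at the limit remains possible.

The expected change is an at least 1.7-fold lower number from compound 3 to compound 4 (0.24 log units; that floor lies within the scatter). For compound 4 the estimated value is 30000 nM, with an expected range of 13000 nM to 55000 nM.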

Compound 4, half-maximal cytotoxic concentration: 28700 nM
The estimate for compound 4 lay 1.0-fold (0.02 log units) above the measured number; low and high end bracket the measured number.
By their numbers in this assay, from the lowest: compounds 1, 4 and 2 (each within the scatter of the next, the first and the last beyond it). At a limit, above all of these: compound 3.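

Compound 3 gives only a limit and not a number: the limit of > 53000 nM in this assay, at which 1 of the 4 values shown sits.

Against that limit, an at least 1.8-fold lower number from compound 3 to compound 4 (0.26 log units; that floor lies within the scatter) is only a floor, so swapping the ring with hetero atoms for 4-hydroxy-3-methoxyphenyl brings a measured number but no firm size of change. With a 1.6-fold lower number from compound 2 to compound 4 (0.21 log units; within the scatter) and a 1.6-fold higher number from compound 1 to compound 4 (0.20 log units; within the scatter) both within the scatter, 4-hydroxy-3-methoxyphenyl on this saturated chain carbon cannot be told apart from the 2-aminophenyl of compound 2, nor the 4-hydroxy-3-methoxybenzyl group from the 4-hydroxyphenyl of compound 1.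

Still open, from the compounds shown here alone, is whether the carbon-only ring itself or its hydroxy and methoxy groups account for the measured number of compound 4. A plain phenyl or a pyridin-4-yl ring at this place would help separate these two readings.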